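A few compounds are considered here, and "the series" means these few. Any claim that something is new, unique, unknown or untested is made for them only; others in the source may bear on it.

Compound 1 `Cc1nc(S(C)(=O)=O)ccc1Oc1ncnc(OC2CCN(C(=O)OC(C)F)CC2)c1F` gives 65.5 nM in a functional assay on isolated protein for inhibition of Glucose-dependent insulinotropic receptor (Homo sapiens), read by HTRF and cAMP accumulation; a higher number here means that more compound is needed for the effect, a lower number that less compound is needed.
Compound 2 `Cc1nc(S(C)(=O)=O)ccc1Oc1ncnc(OC2CCN(C(=O)C3(F)CCC3)CC2)c1F` gives 24.7 nM in this assay.
Compound 3 `Cc1nc(S(C)(=O)=O)ccc1Oc1ncnc(OC2CCN(C(=O)C3(C)CC3)CC2)c1F` gives 761 nM in this assay.

Among these three, compound 3 stands with the highest number: the nearest is compound 1, separated by a 12-fold higher number from compound 1 to compound 3 (1.07 log units; beyond the scatter), and the furthest is compound 2, separated by a 31-fold higher number from compound 2 to compound 3 (1.49 log units; beyond the scatter). Compound 4 `Cc1nc(S(C)(=O)=O)ccc1Oc1ncnc(OC2CCN(C(=O)c3noc(C(C)(C)F)n3)CC2)c1F` has not yet been measured. It differs from compound 3 at a single point: a group of 9 heavy atoms (5 carbon, 2 nitrogen, 1 oxygen, 1 fluorine; one five-membered aromatic ring with 3 hetero atoms) in place of a group of 4 heavy atoms (4 carbon; one three-membered non-aromatic ring of carbon only), on a carbonyl carbon. The two steps that end at compound 3 bear directly on this change, since each of them also swaps the group on that same carbonyl carbon, and both are large, with the 1-methylcyclopropyl of compound 3 giving the far higher number in each case. The step of a 2.7-fold lower number from compound 1 to compound 2 (0.42 log units; beyond the scatter) adds that two alternatives at this position can still differ modestly between themselves. Among the measured compounds shown here, no measured compound carries an aromatic ring at this position, so the size of the step for compound 4 is uncertain, but leaving the 1-methylcyclopropyl has so far always meant a large drop. Compound 4 is therefore expected to give a lower number than compound 3, by a step near an 11-fold lower number from compound 3 to compound 4 (1.04 log units; beyond the scatter). The estimate for compound 4 is 70 nM, with a range from 15 nM to 350 nM.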

Compound 4, half-maximal effective concentration: 14 nM
Estimate against measurement, compound 4: 5.0-fold (0.70 log units) above, and the stated range ends above it.
By their numbers in this assay, from the lowest: compounds 4 and 2 (each within the scatter of the next); then compound 1; then compound 3.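

In this assay, compound 4 brings the first aromatic ring onto this carbonyl carbon, and that ring, with its three hetero atoms, proves compatible with a low number: a 1.8-fold lower number from compound 2 to compound 4 (0.25 log units; within the scatter), so compound 2 and compound 4 cannot be told apart, even though their groups share neither ring size nor aromatic character. The other two steps place the new group clearly apart from both earlier groups, with a 54-fold lower number from compound 3 to compound 4 (1.74 log units; beyond the scatter) as the largest change at this position among the four compounds and a 4.7-fold lower number from compound 1 to compound 4 (0.67 log units; beyond the scatter) as a smaller but real gain over the ring-free group of compound 1. Nothing available here accounts for these differences.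

The compounds shown leave open whether the aromatic ring or the fluorine-bearing chain it carries matters more, a question that the same ring bearing a methyl or a tert-butyl group in place of that chain could address. They also leave open whether other aromatic rings, such as phenyl or pyridine, would behave like this one on the same carbonyl carbon.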